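A few compounds are considered here, and "the series" means these few. Any claim that something is new, unique, unknown or untested is made for them only; others in the source may bear on it.

Measured so far:
- compound 1 `COc1ccc(OCCOc2ccc3c(c2)C(=C(C)C)C(=O)N3)cc1`, in an assay on cells for inhibition of Amine oxidase [flavin-containing] B (Homo sapiens), read by fluorescence, with stated times of 30 min and 15 min, tested at 1 uM; a higher number here means more inhibition at the concentration tested (going by the name of the read-out), a lower number less inhibition: "not active" (no number reported)
- compound 2 `Cn1c(=O)[nH]c2cc(OCc3ccccc3)ccc21`: "not active" (no number reported)
- compound 3 `Cn1c(=O)[nH]c2cc(OCc3cccc(Cl)c3)ccc21`: 23.4%

Compound 1 stands without a single number in this assay; its entry is a plain "not active", as is that of compound 2, so the numbers do not place it relative to compound 3. Among the measured compounds shown here, no step between measured compounds is available for comparison. Compound 4 `CC(C)=C1C(=O)Nc2ccc(OCCOc3ccccc3)cc21` differs from compound 1 by hydrogen in place of methoxy on an aromatic carbon. With compound 1 reported as "not active" (no number reported) and nothing to measure a step against, the expectation for this assay is no change beyond the scatter, the read-out staying low. Compound 4 is expected to give 8%, within a range from 0% to 25%, and a report of "not active" without a number remains a likely outcome.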

Compound 4, a percentage reported as inhibition, at one concentration (the size of the read-out at that concentration, not a potency): "not active" (no number reported)
Compound 4: no number reported, so the estimate cannot be set against anything.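

In this assay compound 1 and compound 4 both stand without a number, so no step can be read between them. The compounds shown leave open whether going from 4-methoxyphenyl to phenyl changes inhibition at all. No supporting evidence bears on this result.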